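This account rests on a few compounds, and the source may have more. Where it says the series, first, only, none or still open, it means among the compounds named here.

Compound 1 `O=S(=O)(Nc1ccc(Cl)cc1Cl)c1ccc(-c2cnc(C3CC3)o2)cc1`: 74500 nM
Compound 2 `O=S(=O)(Nc1ccccc1Cl)c1ccc(-c2cnc(C3CC3)o2)cc1`: 49700 nM
Compound 3 `O=S(=O)(Nc1ccc(Cl)c(F)c1)c1ccc(-c2cnc(C3CC3)o2)cc1`: 63000 nM

In a functional assay on cells (leukaemia cell line, Homo sapiens) for inhibition, read by sulforhodamine B assay, with a stated time of 48 h (on this read-out lower numbers stand for stronger inhibition of growth and higher numbers for weaker inhibition of growth), compound 3 holds the second highest of these three numbers, and its gaps to compound 1 and to compound 2 both lie within the scatter. Compound 4 `Cc1cc(Cl)cc(NS(=O)(=O)c2ccc(-c3cnc(C4CC4)o3)cc2)c1` differs from compound 3 in one place: 3-chloro-5-methylphenyl in place of 4-chloro-3-fluorophenyl on a sulfonamide nitrogen. Two measured steps also exchange the ring on a sulfonamide nitrogen, a 1.2-fold lower number from compound 1 to compound 3 (0.07 log units; within the scatter) and a 1.3-fold higher number from compound 2 to compound 3 (0.10 log units; within the scatter), while a third, a 1.5-fold lower number from compound 1 to compound 2 (0.18 log units; within the scatter), puts hydrogen in place of chloro. None of these moved beyond the scatter, so for compound 4 no shift beyond the scatter is expected in this assay in either direction. Compound 4 is therefore estimated at 60000 nM, with a range from 30000 nM to 120000 nM. The expected step is a 1.1-fold lower number from compound 3 to compound 4 (0.02 log units; within the scatter).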

Compound 4, concentration for total growth inhibition: 7040 nM
Compound 4: the middle estimate sits 8.5-fold (0.93 log units) above what was measured; the measured number lies below the stated range.
By their numbers in this assay, from the lowest: compound 4; then compounds 2, 3 and 1 (each within the scatter of the next).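

In this assay the ring on the sulfonamide nitrogen turns out to matter: the three earlier rings stayed within the scatter of one another, yet 3-chloro-5-methylphenyl brings an 8.9-fold lower number from compound 3 to compound 4 (0.95 log units; beyond the scatter), a 7.1-fold lower number from compound 2 to compound 4 (0.85 log units; beyond the scatter) and an 11-fold lower number from compound 1 to compound 4 (1.02 log units; beyond the scatter). This ring carries a methyl, which none of the earlier rings has, and compound 4 is the strongest of the four. Nothing available explains why this ring stands apart. Whether the methyl alone accounts for the step remains open, since the chloro also sits differently in compound 4. Going by these compounds, how an amine or a carboxylic acid on this ring would behave also remains open.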